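Chloro in Place of Methyl, Measured Once and Expected Again

The compounds below may be only part of what the source reports. "The series", "measured", "known", "first", "only" and "open" are said of these compounds alone.

Of the compounds shown here, three have been measured in a functional assay on NCI-H226 cells (Homo sapiens) for inhibition, read by MTT assay, with a stated time of 72 h; on this read-out higher numbers stand for weaker inhibition of growth and lower numbers for stronger inhibition of growth. Compound 1, `Cc1ccc(-c2cc(N)n(-c3cccc(Cl)c3)n2)cc1`, gives 63500 nM in this assay. Compound 2, `Nc1cc(-c2ccc(Cl)cc2)nn1-c1cccc(Cl)c1`, gives 75100 nM. Compound 3, `Cc1ccc(-c2cc(/N=C/N(C)C)n(-c3ccc(Br)cc3)n2)cc1`, gives 73900 nM. The values of compound 2 and compound 3 lie within the scatter of each other, as do those of compound 1 and compound 3, so no order among the three can be read from these numbers.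

Compound 1 and compound 2 differ in one place, (chloro in place of methyl on an aromatic carbon), and that change brought a 1.2-fold higher number from compound 1 to compound 2 (0.07 log units; within the scatter). The difference between the core of compound 1 and the core of compound 3 is not broken down here.

Compound 4, `CN(C)/C=N/c1cc(-c2ccc(Cl)cc2)nn1-c1ccc(Br)cc1`, is not yet measured. Within the data shown here, it differs from compound 3 by chloro in place of methyl on an aromatic carbon, the same change as the one from compound 1 to compound 2, made at a place described in the same words. Among the measured compounds shown here, the only measured instance of this change, from compound 1 to compound 2, stayed within the scatter, and that instance is all the data offer on it.

On that basis compound 4 is expected to give a value near that of compound 3, with an estimated step of a 1.2-fold higher number from compound 3 to compound 4 (0.06 log units; within the scatter) in this assay. The estimate for compound 4 in this assay is 85000 nM, with a range from 45000 nM to 160000 nM.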

Compound 4, concentration for 50% growth inhibition: 59800 nM
Estimate against measurement, compound 4: 1.4-fold (0.15 log units) above, and the stated range covers the measured number.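

In this assay, chloro in place of methyl on an aromatic carbon, para to a large group, gave a 1.2-fold lower number from compound 3 to compound 4 (0.09 log units; within the scatter) on the core of compound 3, so this second instance also stayed within the scatter. Set beside the first instance, the change reads the same on both cores, since the two steps do not differ beyond what repeated measurement would produce: the same change on two cores in this assay, a 1.2-fold higher number (0.07 log units; within the scatter) from compound 1 to compound 2 and a 1.2-fold lower number (0.09 log units; within the scatter) from compound 3 to compound 4, 1.5-fold (0.16 log units) apart, within the scatter of two such steps. Among these compounds, this shows that, on these two cores, exchanging methyl for chloro at this place moved the number by no more than the assay can resolve, but it does not show that the change has no effect at all, it gives no direction for the step, and two pairs cannot establish a rule for the whole series.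

The compounds shown leave open whether any other group at this place, such as an amine, a carboxylic acid or a longer chain, would give a step beyond the scatter. They also leave open whether methyl and chloro would remain interchangeable on a core that differs from those of compound 1 and compound 3.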